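A few compounds are considered here, and "the series" means these few. Any claim that something is new, unique, unknown or untested is made for them only; others in the source may bear on it.

Among the measured compounds shown here, compound 2 `CCCCSS[C@H]1C[C@H](n2cc(C)c(=O)[nH]c2=O)O[C@@H]1CO` is one of two compounds measured so far in a functional assay on MOLT-4 cells (Homo sapiens) for cytotoxicity (on this read-out lower numbers stand for stronger inhibition and higher numbers for weaker inhibition), where compound 2 gives 28000 nM. Compound 1 `Cc1cn([C@H]2C[C@H](SSC(Cl)(Cl)Cl)[C@@H](CO)O2)c(=O)[nH]c1=O` gives 55000 nM in this assay. For the measured compounds named here, the single measured step, a 2.0-fold lower number from compound 1 to compound 2 (0.29 log units; within the scatter), exchanges the group on the sulfur and stays within the scatter. Compound 3 `CCCCCCSS[C@H]1C[C@H](n2cc(C)c(=O)[nH]c2=O)O[C@@H]1CO` differs from compound 2 by ethyl in place of hydrogen on a saturated chain carbon, four bonds along the chain from a sulfur. Going by the values given here, no measured step lengthens the chain in this way, so the only guide is the small size of the one step seen. The step of no change at the digits printed from compound 2 to compound 3 (within the scatter) is therefore expected to be small, with no direction beyond the scatter. Compound 3 is estimated at 28000 nM, between 12000 nM and 65000 nM.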

Compound 3, half-maximal inhibitory concentration: 27000 nM
The estimate for compound 3 lay 1.0-fold (0.02 log units) above the measured number; the measured number falls inside the stated range.
By their numbers in this assay, from the lowest: compounds 3, 2 and 1 (each within the scatter of the next, the first and the last beyond it).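

With ethyl added to the butyl chain, the result is a 1.0-fold lower number from compound 2 to compound 3 (0.02 log units; within the scatter) in this assay and so the two numbers cannot be told apart: at this chain position, the extra carbons bring no visible difference. Hexyl in place of trichloromethyl on the sulfur gives a 2.0-fold lower number from compound 1 to compound 3 (0.31 log units; beyond the scatter) and thus the first step here to pass the scatter, though only modestly. Butyl in that same exchange stayed within the scatter, so the margin over compound 1 remains slim. On these data alone, whether a longer chain such as decyl, or an amine at the chain end, would stand apart from compound 3 remains open. Nothing measured here explains either step.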